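The compounds below may be only part of what the source reports. "The series", "measured", "known", "first", "only" and "open" are said of these compounds alone.

Working notes on the series.

Three amides on a shared core have been measured in a functional assay on MCF7 cells (Homo sapiens) for antiproliferative activity, read by MTT assay, with a stated time of 72 h; on this read-out higher numbers stand for weaker inhibition and lower numbers for stronger inhibition. Compound 1 `CNc1cc(C)c2cc(NC(=O)c3ccc(Cl)c(Cl)c3)ccc2n1` gives 2520 nM. Compound 3 `Cc1cc(N2CCN(C(C)C)CC2)nc2ccc(NC(=O)c3ccc(Cl)c(Cl)c3)cc12` gives 1710 nM; the only listed step, a 1.5-fold lower number from compound 1 to compound 3 (0.17 log units; within the scatter), concerns the amine on the core and not the benzoyl ring. Compound 2 `CCN1CCN(c2cc(C)c3cc(NC(=O)c4ccccc4)ccc3n2)CC1` gives 14200 nM, the highest of the three numbers, and its gaps to compound 1 and compound 3 are both beyond the scatter. Compounds 1 and 3 differ from compound 2 in more than one place, so their values show only that the two dichloro-substituted benzoyl compounds sit at lower numbers.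

Compound 4 `CCc1ccc(C(=O)Nc2ccc3nc(N4CCN(CC)CC4)cc(C)c3c2)cc1` differs from compound 2 by ethyl in place of hydrogen on an aromatic carbon, on an aromatic carbon of a six-membered aromatic ring of carbon only, para to a large group. For the measured compounds named here, no measured step bears on this change in this assay. Compounds 1 and 3 hint that a substituted benzoyl ring may run lower than the bare one, but the confounded amine change leaves this uncertain; a modest lowering, a 2.0-fold lower number from compound 2 to compound 4 (0.31 log units; beyond the scatter), is therefore expected, with wide bounds. For compound 4 the estimate is 7000 nM, between 2500 nM and 20000 nM.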

Compound 4, half-maximal inhibitory concentration: 3060 nM
The estimate for compound 4 lay 2.3-fold (0.36 log units) above the measured number; the measured number falls inside the stated range.
By their numbers in this assay, from the lowest: compounds 3, 1 and 4 (each within the scatter of the next); then compound 2.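

On the benzoyl ring, this assay now shows a 4.6-fold lower number from compound 2 to compound 4 (0.67 log units; beyond the scatter) for ethyl in place of hydrogen on an aromatic carbon, para to a large group, with the amine on the shared core unchanged. The dichloro-substituted compounds 1 and 3 differ from compound 2 in more than one place, whereas this single-place comparison ties a change beyond the scatter to this position alone. Nothing available here accounts for the size of this step.

Still open, from the compounds shown here alone, is whether a methyl, a longer chain such as propyl, an amine or a carboxylic acid at this position would follow ethyl. Also open, going by these compounds, is whether ethyl would give a similar step with methylamino or 4-isopropylpiperazin-1-yl on the core.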